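The source may hold more compounds than are shown below. What is called first, only, known or untested is meant among the compounds shown, and "the series" means these compounds.

In a toxicity assay on NIH3T3 cells (Mus musculus) for cytotoxicity, read by resazurin assay (on this read-out higher numbers stand for an effect only at larger amounts of compound and lower numbers for an effect already at smaller amounts), compound 1 `COC(=O)c1ccc(NCc2cncn2Cc2ccccc2C)cc1-c1ccccc1` gives 10000 nM, and compound 2 `COC(=O)c1ccc(NCc2cncn2Cc2ccccc2N)cc1-c1ccccc1` gives 25000 nM. Compound 3 `COC(=O)c1ccc(NCc2cncn2Cc2cccc(C#N)c2)cc1-c1ccccc1` gives > 10000 nM, which is a limit of the assay and not a number. Compound 3 therefore has no exact place on the scale.

Compound 4 `COC(=O)c1ccc(NCc2cncn2Cc2ccc(C#N)cc2)cc1-c1ccccc1` has the same atoms, joined differently: 4-cyanophenyl in place of 3-cyanophenyl on a saturated chain carbon bound to an aromatic nitrogen.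

Three measured steps alter the group at this place, though none makes this exact swap. Two of them cannot be sized: a number no lower from compound 1 to compound 3 (the limit leaves the size open) and a step that the limit leaves unreadable from compound 2 to compound 3. Within the data shown here, the only readable step shows a 2.5-fold higher number from compound 1 to compound 2 (0.40 log units; beyond the scatter), a modest change, so no step beyond the usual scatter is expected here. The estimated step is a step that the limit leaves unreadable from compound 3 to compound 4.

Compound 4 may also return only a limit. If it gives a number, compound 4 is expected at about 15000 nM, with an estimated range from 6000 nM to 40000 nM.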

Compound 4, half-maximal effective concentration: > 10000 nM
Compound 4 ended at the assay's limit (the forecaster's own chance of this, stated with the estimate: 45%); the middle value lies beyond the limit too.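

Neither the 3-cyanobenzyl group of compound 3 nor the 4-cyanobenzyl group of compound 4 gives an exact number at this place in this assay, so moving the nitrile around the ring adds a second result that is a limit and not a number: the limit of > 10000 nM in this assay, at which 2 of the 4 values shown sit. What the new result does give is a number no lower from compound 1 to compound 4 (the limit leaves the size open) with no size attached, and the other two new steps cannot be read, so no size can be given for this swap or for the comparison with compound 2.

On these data alone, the exact values of compound 3 and compound 4 stay open, and so does whether the two differ at all. Also open, as far as these compounds go, is how a carboxylic acid or a methoxy group in place of the nitrile on this ring would read out.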